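The source may hold more compounds than are shown below. What is called first, only, known or untested is meant among the compounds shown, and "the series" means these compounds.

Of the compounds shown here, three have so far been measured in an ADME assay on RAW264.7 cells (Mus musculus) for cytotoxicity, read by MTT assay, with a stated time of 24 h; on this read-out higher numbers stand for lower toxicity in this test and lower numbers for higher toxicity in this test. Compound 1 `O=C(Nc1ccc(F)cc1F)c1cc(Br)ccc1O` gives 13800 nM. Compound 2 `O=C(Nc1ccc(F)cc1F)c1cc(F)ccc1O` gives 15700 nM in this assay. Compound 3 `O=c1oc2ccc(F)cc2c(=O)n1-c1ccc(F)cc1F` gives 19900 nM in this assay. Compound 2 and compound 1 differ in a single place, (bromo in place of fluoro on an aromatic carbon), and this change made a 1.1-fold lower number from compound 2 to compound 1 (0.06 log units; within the scatter). The difference between the core of compound 2 and the core of compound 3 is not broken down here. Compound 4 `O=c1oc2ccc(Br)cc2c(=O)n1-c1ccc(F)cc1F` has not yet been measured in this assay; it differs from compound 3 by bromo in place of fluoro on an aromatic carbon. The change occurs in two pairs among these compounds and is the same kind of change as the one from compound 2 to compound 1, though the place is not identical: in compound 1 the new group sits meta to a large group and para to a hydroxy group, whereas in compound 4 it sits on a ring that is part of a fused or bridged system of two rings, meta to a fused ring and para to a fused ring. Because the earlier change gave a 1.1-fold lower number from compound 2 to compound 1 (0.06 log units; within the scatter), the expected step is a 1.1-fold lower number from compound 3 to compound 4 (0.04 log units; within the scatter). On that basis compound 4 is expected to give about 18000 nM in this assay.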

Compound 4, half-maximal cytotoxic concentration: 16000 nM
Estimate against measurement, compound 4: 1.1-fold (0.05 log units) above; the range from low to high includes it.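

In this assay, the new swap of fluoro for bromo gives a 1.2-fold lower number from compound 3 to compound 4 (0.09 log units; within the scatter). Set beside the earlier swap, the change looks the same on both cores: the same change on two cores in this assay, a 1.1-fold lower number (0.06 log units; within the scatter) from compound 2 to compound 1 and a 1.2-fold lower number (0.09 log units; within the scatter) from compound 3 to compound 4, 1.1-fold (0.04 log units) apart, within the scatter of two such steps

For the compounds shown here, neither step stands clear of the scatter, which means this agreement shows only that the swap makes no readable difference on either of these two cores; it does not show that bromo and fluoro are interchangeable in general, that the result would hold on a third core, or that a change with a large effect would carry across in the same way.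

The compounds shown hold only fluoro and bromo at this place, leaving open what a methoxy group, an amine or a carboxylic acid there would do on either core. Also open, going by these compounds, is whether a change elsewhere in these molecules would move the number beyond the scatter.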